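This account rests on a few compounds, and the source may have more. Where it says the series, first, only, none or still open, it means among the compounds named here.

Compound 1 `CC(=O)N[C@H]1CC[C@H](Nc2cc(-c3csc(NCC4CCOCC4)n3)c(Cl)cn2)CC1` gives 3600 nM in a functional assay on MV4-11 cells (Homo sapiens) for antiproliferative activity, read by CellTiter-Glo, with a stated time of 72 h; a lower number here means a stronger inhibitor of growth, a higher number a weaker inhibitor of growth. Compound 2 `O=C(N[C@H]1CC[C@H](Nc2cc(-c3csc(NCC4CCOCC4)n3)c(Cl)cn2)CC1)C1CC1` reads > 10000 nM in this assay, which is a limit of the assay and not a number. On the numbers shown, compound 2 is held only by the limit of > 10000 nM in this assay, at which 1 of the 2 values shown sits.

Compound 3 `COCC(=O)N[C@H]1CC[C@H](Nc2cc(-c3csc(NCC4CCOCC4)n3)c(Cl)cn2)CC1` changes the same place: methoxymethyl in place of cyclopropyl on a carbonyl carbon. Among the measured compounds shown here, one measured step bears on this, also made on that carbonyl carbon: an at least 2.7-fold higher number from compound 1 to compound 2 (0.44 log units; beyond the scatter). From the compounds shown here alone, it is at least modest and beyond the scatter, and its true size stays open at the upper end. Like the methyl of compound 1, the methoxymethyl group has no ring, though no measured step tests that feature alone. Going by the step of an at least 2.7-fold higher number from compound 1 to compound 2 (0.44 log units; beyond the scatter), a small to modest move toward a lower number in this assay is expected, possibly not far beyond the scatter and possibly ending at the limit again. The expected step is an at least 1.6-fold lower number from compound 2 to compound 3 (0.22 log units; that floor lies within the scatter). For compound 3 the estimated value is 6000 nM, with an expected range of 2500 nM to 14000 nM.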

Compound 3, concentration for 50% growth inhibition: > 10000 nM
Compound 3 was reported as a limit (the forecaster's own chance of this, stated with the estimate: 30%); middle value at least 1.6-fold (0.22 log units) from the limit.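

In this assay, methoxy in place of hydrogen on a saturated chain carbon bound to a carbonyl carbon gives an at least 2.7-fold higher number from compound 1 to compound 3 (0.44 log units; beyond the scatter). A ring on this carbonyl carbon is therefore not required for a move to a higher number: cyclopropyl has a ring and methoxymethyl has none, yet both groups end at the limit of the assay. The step between these two groups cannot be read, since both values are limits and not numbers, and methyl remains the only group at this place with a measured number in the series: the limit of > 10000 nM in this assay, at which 2 of the 3 values shown sit.

From the compounds shown here alone, how far compound 2 and compound 3 lie past the limit stays open, so no order can be given between cyclopropyl and methoxymethyl. Also open, going by these compounds, is whether any group on this carbonyl carbon can give a lower number than the methyl of compound 1, for example a hydrogen, a dimethylaminomethyl amine or a carboxylic acid.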